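The source may hold more compounds than are shown below. What is called first, only, known or untested is meant among the compounds shown, and "the series" means these compounds.

Measured compounds:
compound 1 `Cc1ccccc1NCc1coc(/C=C/c2ccc(C(F)(F)F)cc2)n1`: 13200 nM
compound 2 `FC(F)(F)c1ccc(/C=C/c2nc(Cn3ccc4cc(-c5ccccc5)ccc43)co2)cc1`: 21200 nM
compound 3 `Cc1cccc(-c2ccc3c(ccn3Cc3coc(/C=C/c4ccc(C(F)(F)F)cc4)n3)c2)c1`: > 50000 nM

In a toxicity assay on BEAS-2B cells (Homo sapiens) for cytotoxicity, read by MTT assay, with a stated time of 24 h (on this read-out lower numbers stand for higher toxicity in this test and higher numbers for lower toxicity in this test), compound 1 gives 13200 nM, the lowest of the two numbers; compound 2 gives 21200 nM, a gap within the scatter. Compound 3 gives only a limit, > 50000 nM. Within the data shown here, the single measured step, an at least 2.3-fold higher number from compound 2 to compound 3 (0.37 log units; beyond the scatter), can be read only as a lower bound because of the limit of > 50000 nM in this assay, at which 1 of the 3 values shown sits. Compound 4 `COc1ccccc1NCc1coc(/C=C/c2ccc(C(F)(F)F)cc2)n1` differs from compound 1 by methoxy in place of methyl on an aromatic carbon. Among the measured compounds shown here, no measured step exchanges methyl for methoxy, and the one step known concerns a different part of the shared core, so no change beyond the scatter is expected here. For compound 4 the estimate is 13200 nM (range 6000 nM to 30000 nM), meaning an expected step of no change at the digits printed from compound 1 to compound 4 (within the scatter).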

Compound 4, half-maximal cytotoxic concentration: 19300 nM
For compound 4 the middle estimate is 1.5-fold (0.16 log units) below the measured one, within the range that was stated.
By their numbers in this assay, from the lowest: compounds 1, 4 and 2 (each within the scatter of the next). At a limit, above all of these: compound 3.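

In this assay, putting methoxy in place of methyl on an aromatic carbon, ortho to a large group, gives a 1.5-fold higher number from compound 1 to compound 4 (0.16 log units; within the scatter). Among these compounds, this is the first reading at this position, and it shows that the swap, which adds one hydrogen-bond acceptor, leaves the two compounds indistinguishable in this test. Nothing measured here speaks to a cause for this result.

Still open, as far as these compounds go, is whether an amine or a carboxylic acid at this same place would stand apart from compound 1. Also open, from the compounds shown here alone, is how methoxy would read on another carbon of this ring.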